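From methoxy to hydroxy on compound 1

The source may report more compounds than this note shows. Statements on the series, on what has been measured and on what is new or still open speak of the compounds shown alone.

Measured so far in a functional assay on HCT-116 cells (Homo sapiens) for cytotoxicity, with a stated time of 48 h; a higher number here means a weaker inhibitor, a lower number a stronger inhibitor:
Compound 1 `COc1cc(OC)c(C(=O)/C=C/c2ccccc2SC)c(OC)c1` gives 6800 nM
Compound 2 `COc1cc(OC)c(C(=O)/C=C/c2ccc(Br)cc2)c(OC)c1` gives 6200 nM

For the measured compounds named here, the two measured numbers sit together: the single step, a 1.1-fold lower number from compound 1 to compound 2 (0.04 log units; within the scatter), gives neither compound a rank. Compound 3 `COc1cc(O)c(C(=O)/C=C/c2ccccc2SC)c(OC)c1` changes compound 1 in one place: hydrogen in place of methyl on an oxygen on an aromatic ring, which turns methoxy to hydroxy. The measured step replaces a different group, so it offers no direct guide to this change. No step beyond the scatter is therefore expected in this assay, in either direction. The estimate for compound 3 is 5500 nM, with an expected range from 1800 nM to 14000 nM. The expected step, still only an estimate, is a 1.2-fold lower number from compound 1 to compound 3 (0.09 log units; within the scatter).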

Compound 3, half-maximal inhibitory concentration: 10000 nM
For compound 3 the middle estimate is 1.8-fold (0.26 log units) below the measured one; low and high end bracket the measured number.
By their numbers in this assay, from the lowest: compounds 2, 1 and 3 (each within the scatter of the next).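

In this assay, methoxy to hydroxy on the aromatic ring gives a 1.5-fold higher number from compound 1 to compound 3 (0.17 log units; within the scatter) and so does not separate the two compounds. For the compounds shown here, this is the first view of this oxygen, since the earlier step replaced a different group, and here losing the methyl leaves the cytotoxicity reading within normal repeat variation. No supporting measurement bears on this result. Still open, going by these compounds, is whether a longer chain on this oxygen, or one ending in an amine, would shift the number beyond the scatter. On these data alone, the same change on the core of compound 2 also remains open.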